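Shortening the Long Chain of a Platelet-Activating Factor Antagonist

A few compounds are considered here, and "the series" means these few. Any claim that something is new, unique, unknown or untested is made for them only; others in the source may bear on it.

Compound 1, `CCCCCCCCCCCCCCCCCC1OCC(COCCCCCC[N+](C)(C)C)O1`: 2400 nM
Compound 2, `CCCCCCCCCCCCCCCCCC1OCC(COCCCCCC[n+]2ccccc2)O1`: 3000 nM
Compound 3, `CCCCCCCCCCCCCCCCCC1OCC(COC(=O)CCCCC[n+]2ccsc2)O1`: 1100 nM

In a functional assay (Oryctolagus cuniculus) for inhibition of platelet-activating factor receptor (Cavia porcellus) (on this read-out lower numbers stand for stronger inhibition and higher numbers for weaker inhibition), compound 3 gives the lowest number of the three measured compounds. Its margin over the others is modest but real: a 2.2-fold lower number from compound 1 to compound 3 (0.34 log units; beyond the scatter) and a 2.7-fold lower number from compound 2 to compound 3 (0.44 log units; beyond the scatter) both lie beyond the scatter, whereas compound 1 and compound 2 cannot be told apart, since a 1.3-fold higher number from compound 1 to compound 2 (0.10 log units; within the scatter) falls within it.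

Compound 4, `CCCCCCCCCCCCCC1OCC(COC(=O)CCCCC[n+]2ccsc2)O1`, keeps the whole of compound 3 except for one change: hydrogen in place of butyl on a saturated chain carbon, ten or more bonds along the chain from a saturated ring carbon. The long saturated chain is thereby cut shorter by that butyl piece. Going by the values given here, none of the measured steps bears on this part of the molecule; each of them alters the group at the opposite end of the shared core, so there is no direct guide to how the chain length itself matters. The expectation is therefore loosely held. Compound 4 is expected to give 2000 nM, within a range of 700 nM to 6000 nM, which would mean an estimated step of a 1.8-fold higher number from compound 3 to compound 4 (0.26 log units; within the scatter).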

Compound 4, half-maximal inhibitory concentration: 20000 nM
Compound 4: middle estimate off by 10-fold (1.00 log units), on the low side, outside the stated range (above it).
By their numbers in this assay, from the lowest: compound 3; then compounds 1 and 2 (each within the scatter of the next); then compound 4.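

In this assay, going by these compounds alone, taking butyl off the long chain gives an 18-fold higher number from compound 3 to compound 4 (1.26 log units; beyond the scatter), a far bigger step than any among the earlier compounds. In this one pair, then, the length of the long chain counts for more than the group changes in those earlier steps, a part of the molecule that they left untouched. No measurement at hand explains why the number rises so steeply.

A single step cannot show whether the number climbs gradually as the chain shortens or jumps sharply at one particular length. It also leaves open whether a chain longer than that of compound 3, or one ending in a phenyl ring or a carboxylic acid, would lower the number further.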